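The source may report more compounds than this note shows. Statements on the series, on what has been measured and on what is new or still open speak of the compounds shown alone.

Working notes on the series.

Two compounds have numbers in a functional assay on MCF7 cells (Homo sapiens) for inhibition, read by CCK-8 assay, with a stated time of 48 h; a higher number here means a weaker inhibitor of growth, a lower number a stronger inhibitor of growth. Compound 1, `Cc1ccccc1Nc1nc(Nc2cccnc2)ncc1Cl`, gives 56500 nM in this assay. Compound 2, `CN1CCN(c2ccc(Nc3ncc(Cl)c(NCc4ccccc4)n3)nc2)CC1`, gives 17300 nM in this assay. Compound 2 holds the lower of the two numbers; the gap to compound 1 is beyond the usual scatter, so within this pair compound 2 is the stronger inhibitor of growth. Going by the values given here, no single-point step between measured compounds is available, so nothing measured yet shows what a single change does here.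

Compound 3, `Cc1cccc(Nc2nc(Nc3ccc(N4CCN(C)CC4)cn3)ncc2Cl)c1`, has not been measured in this assay. Compared with compound 2 the difference is 3-methylphenyl in place of benzyl on a nitrogen on an aromatic ring: the same atoms joined differently, benzylamino becoming (3-methylphenyl)amino on a nitrogen on an aromatic ring whose other neighbour is aromatic carbon, with the methylpiperazine-bearing part of compound 2 kept.

Among the compounds with values here, with no measured step of this kind, the expectation rests only on compound 2 and its value 17300 nM. A moderate step toward a lower number is expected, a 2.9-fold lower number from compound 2 to compound 3 (0.46 log units; beyond the scatter), though a result within the scatter would not surprise. Compound 3 is estimated at 6000 nM in this assay, with a range from 1500 nM to 25000 nM.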

Compound 3, concentration for 50% growth inhibition: 7160 nM
Beside the measured number, compound 3's estimate is 1.2-fold (0.08 log units) below it; the range from low to high includes it.
By their numbers in this assay, from the lowest: compound 3; then compound 2; then compound 1.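

In this assay, going by these compounds alone, the change gives a 2.4-fold lower number from compound 2 to compound 3 (0.38 log units; beyond the scatter) and is the first single-place step, so it shows that this position, on a nitrogen on an aromatic ring, responds to the group it carries. Benzyl and 3-methylphenyl have the same heavy-atom count and each has one six-membered aromatic ring of carbon only, so joining the same atoms differently is enough to move the number beyond the usual scatter, though only modestly, with the methylpiperazine-bearing part kept. No measurement shown bears on why the number moves with this change.

A single step cannot separate the effect of attaching the ring directly to the nitrogen from the effect of the methyl on that ring; phenyl without the methyl, 3-methoxyphenyl, or a longer chain such as 2-phenylethyl on the same nitrogen would bear on that. From the compounds shown here alone, it also remains open whether the step carries over when the methylpiperazine is replaced by another amine such as morpholine.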